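Chain Extension on Two Hydroxamate Cores

A few compounds are considered here, and "the series" means these few. Any claim that something is new, unique, unknown or untested is made for them only; others in the source may bear on it.

Measured compounds:
compound 1, `Nc1ncnc2c1c(-c1cnc3[nH]ccc3c1)nn2CCCCCCCCCC(=O)NO`: 7560 nM
compound 2, `Nc1ncnc2c1c(-c1cnc3[nH]ccc3c1)nn2CCCCCCC(=O)NO`: 22000 nM
compound 3, `Nc1nc2cc(-c3nn(CCCCCC(=O)NO)c4ncnc(N)c34)ccc2o1`: 15400 nM

All three were tested in a functional assay on HeLa cells (Homo sapiens) for inhibition, read by MTT assay, with a stated time of 72 h; a lower number here means a stronger inhibitor, a higher number a weaker inhibitor. Compounds 1 and 2 share one core and differ in one place: 3-(hydroxycarbamoyl)propyl in place of hydroxycarbamoyl on a saturated chain carbon, six bonds along the chain from an aromatic nitrogen. This change gave a 2.9-fold lower number from compound 2 to compound 1 (0.46 log units; beyond the scatter). Compound 3 carries a different core; the difference between the two cores is not broken down here. Its value in this assay and that of compound 2 lie within the usual scatter of each other, while compound 1 shows a lower number than compound 3.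

Compound 4, `Nc1nc2cc(-c3nn(CCCCCCCCC(=O)NO)c4ncnc(N)c34)ccc2o1`, has not yet been measured. It stands to compound 3 as compound 1 stands to compound 2: 3-(hydroxycarbamoyl)propyl in place of hydroxycarbamoyl on a saturated chain carbon, five bonds along the chain from an aromatic nitrogen. The place differs slightly, five bonds from the aromatic nitrogen rather than six, so this is the same kind of change rather than the same change. Resting on compound 3 with 15400 nM and on the step of a 2.9-fold lower number from compound 2 to compound 1 (0.46 log units; beyond the scatter), the step from compound 3 to compound 4 is expected to be a 2.8-fold lower number from compound 3 to compound 4 (0.45 log units; beyond the scatter). Compound 4 is therefore estimated at 5500 nM, likely between 2000 nM and 14000 nM.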

Compound 4, half-maximal inhibitory concentration: 10200 nM
Compound 4: middle estimate off by 1.9-fold (0.27 log units), on the low side; the measured number falls inside the stated range.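

In this assay, 3-(hydroxycarbamoyl)propyl in place of hydroxycarbamoyl on the core of compound 3 gave a 1.5-fold lower number from compound 3 to compound 4 (0.18 log units; within the scatter) and so, on this core alone, the change has no effect that can be told from repeated measurement. For the compounds shown here, this does not show that the change lowers the number on every core: only two pairs in a single assay are available, and only one of the two steps lies beyond the scatter. Even so, the two steps cannot be told apart, so a change of similar size on both cores remains possible, though it is not proven: the same change on two cores in this assay, a 2.9-fold lower number (0.46 log units; beyond the scatter) from compound 2 to compound 1 and a 1.5-fold lower number (0.18 log units; within the scatter) from compound 3 to compound 4, 1.9-fold (0.28 log units) apart, within the scatter of two such steps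

The compounds shown leave open whether a longer chain than that of compound 4, or a shorter one than that of compound 3, would follow the same course on either core. They also leave open what a carboxylic acid or a primary amide in place of the hydroxycarbamoyl group would give at the end of these chains.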